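A urea nitrogen substituent change at the anilide end

The compounds below may be only part of what the source reports. "The series", "measured", "known", "first", "only" and "open" are said of these compounds alone.

Three ureas sharing a common core, all carrying a piperidinylmethyl-substituted phenoxypropyl chain, have been examined in an assay on isolated protein for inhibition of histamine H2 receptor (Cavia porcellus); a lower number here means tighter binding, a higher number weaker binding. Compound 1 `O=C(NCCCOc1cccc(CN2CCCCC2)c1)Nc1cccc(C(F)(F)F)c1` gives 813 nM. Compound 2 `CC(C)CNC(=O)NCCCOc1cccc(CN2CCCCC2)c1` gives 170 nM, and compound 3 `CC(C)(C)NC(=O)NCCCOc1cccc(CN2CCCCC2)c1` gives 2090 nM. Compound 3 therefore stands highest of the three, a 2.6-fold higher number from compound 1 to compound 3 (0.41 log units; beyond the scatter) and a 12-fold higher number from compound 2 to compound 3 (1.09 log units; beyond the scatter).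

Compound 4 `COc1ccc(OC)c(NC(=O)NCCCOc2cccc(CN3CCCCC3)c2)c1` is not yet measured. It differs from compound 3 in one place: 2,5-dimethoxyphenyl in place of tert-butyl on an amide-type nitrogen. For the measured compounds named here, the step that bears most directly on this change is the one from an aryl group to tert-butyl on the same nitrogen, which gave a 2.6-fold higher number from compound 1 to compound 3 (0.41 log units; beyond the scatter); the move in the other direction, back to an aryl group, would be expected to undo a change of about that size. The substituents on the ring differ, however, and the data hold no aryl other than that of compound 1, so the size of this expectation is uncertain. A modest decrease is expected in this assay, in the direction of compound 1.

For compound 4 the estimate is 700 nM, with a range from 200 nM to 2500 nM, meaning an expected 3.0-fold lower number from compound 3 to compound 4 (0.48 log units; beyond the scatter).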

Compound 4, dissociation constant: 158 nM
Estimate against measurement, compound 4: 4.4-fold (0.65 log units) above; measured number below the stated range.
By their numbers in this assay, from the lowest: compounds 4 and 2 (each within the scatter of the next); then compound 1; then compound 3.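

With the second aryl group in the series, the nitrogen's substituent proves far more consequential in this assay than compound 1 alone suggested: replacing tert-butyl with 2,5-dimethoxyphenyl gives a large step (a 13-fold lower number from compound 3 to compound 4 (1.12 log units; beyond the scatter)), well beyond the modest step separating tert-butyl from 3-(trifluoromethyl)phenyl. The identity of the aryl group therefore matters at this position, as the change from one ring to the other also gives a step beyond the scatter (a 5.1-fold lower number from compound 1 to compound 4 (0.71 log units; beyond the scatter)), and an aryl group is not in itself a disadvantage relative to the alkyl group of compound 2, since 2,5-dimethoxyphenyl and isobutyl cannot be told apart (a 1.1-fold lower number from compound 2 to compound 4 (0.03 log units; within the scatter)). No measurement at hand accounts for these differences.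

The compounds shown leave open whether the two methoxy groups act together or one alone carries the difference, which unsubstituted phenyl and a ring with a single methoxy group would help to settle. They also leave open how a longer chain such as n-hexyl would compare on this nitrogen with isobutyl and 2,5-dimethoxyphenyl.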